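The source may report more compounds than this note shows. Statements on the series, on what has been measured and on what is new or still open speak of the compounds shown alone.

Compound 3 (`CCCCCOCc1[nH]c2ccc([N+](=O)[O-])cc2c(=O)c1C(=O)OCC`) stands second highest of three numbers in a physicochemical assay for solubility, read by HPLC, at pH 7.4; on this read-out lower numbers stand for lower solubility and higher numbers for higher solubility: compound 3 gives 15000 nM, compound 2 (`CCCCCCCc1[nH]c2ccc([N+](=O)[O-])cc2c(=O)c1C(=O)OCC`) gives 5000 nM, a lower number, and compound 1 (`CCOCCCCc1cc(=O)c2cc([N+](=O)[O-])ccc2[nH]1`) gives 50000 nM, a higher one.

The next structure is compound 4 (`CCOCCCCc1[nH]c2ccc([N+](=O)[O-])cc2c(=O)c1C(=O)OCC`). The change is 3-ethoxypropyl in place of pentyloxy on a saturated chain carbon bound to an aromatic carbon. Cut one bond further out, the same difference reads (pentyloxy)methyl to 4-ethoxybutyl. The two compounds have the same atoms, joined differently.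

Within the data shown here, only one measured step bears on this: a 3.0-fold higher number from compound 2 to compound 3 (0.48 log units; beyond the scatter), a modest one, with pentyloxy in place of hexyl on the same kind of carbon. That step replaced hexyl, whereas the step under consideration keeps the atoms and only rejoins them, so a smaller step is expected in this assay, probably none beyond the scatter and with no favoured direction. Among the measured compounds shown here, no step in one place joins compound 1 to a measured compound, so its value sizes nothing here. The estimated change is no change at the digits printed from compound 3 to compound 4 (within the scatter). For compound 4 the expected value is 15000 nM, with an estimated range of 7000 nM to 35000 nM.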

Compound 4, solubility: 5000 nM
For compound 4 the middle estimate is 3.0-fold (0.48 log units) above the measured one; the whole stated range lies above it.
By their numbers in this assay, from the lowest: compounds 2 and 4 (each within the scatter of the next); then compound 3; then compound 1.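

In this assay, rejoining the same atoms, (pentyloxy)methyl to 4-ethoxybutyl, gives a 3.0-fold lower number from compound 3 to compound 4 (0.48 log units; beyond the scatter), so at this saturated chain carbon bound to an aromatic carbon the arrangement of the chain alone gives a step beyond the scatter, and equal atom counts do not make two chains interchangeable here. Ethoxy in place of propyl on a saturated chain carbon, four bonds along the chain from an aromatic carbon, gives no change at the digits printed from compound 2 to compound 4 (within the scatter), so at this place the exchange shows nothing beyond the scatter, and the earlier step of a 3.0-fold higher number from compound 2 to compound 3 (0.48 log units; beyond the scatter) does not hold for every chain that carries an oxygen. Among these compounds, with the 4-ethoxybutyl chain held constant, ethoxycarbonyl in place of hydrogen on an aromatic carbon gives a 10-fold lower number from compound 1 to compound 4 (1.00 log units; beyond the scatter), the first reading of that position and a step beyond the scatter.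

Still open, from the compounds shown here alone, is whether an amine or a carboxylic acid in place of the ethoxycarbonyl, or a longer chain carrying its oxygen elsewhere, would follow these steps. Nothing measured here gives a reason for any of the three new steps.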